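Methyl in Place of Fluoro on the Shared Core

A few compounds are considered here, and "the series" means these few. Any claim that something is new, unique, unknown or untested is made for them only; others in the source may bear on it.

Measured so far:
compound 1, `COc1ccc(S(=O)(=O)c2cnc3ccc(F)cc3c2N2CCC(C)CC2)cc1`: 85%
compound 2, `Cc1ccc(S(=O)(=O)c2cnc3ccc(F)cc3c2N2CCC(C)CC2)cc1F`: 86%
compound 3, `CC1CCN(c2c(S(=O)(=O)c3ccccc3)cnc3ccc(F)cc23)CC1`: 40%

All three values come from an assay on isolated protein for displacement of a labelled ligand from metabotropic glutamate receptor 5 (Homo sapiens), with a stated time of 60 min, tested at 1 uM; a higher number here means more inhibition at the concentration tested (going by the name of the read-out), a lower number less inhibition. Compound 1 stands second highest of the three: compound 2 sits a number 1 percentage points higher from compound 1 to compound 2 (within the scatter), within the scatter, while compound 3 sits a number 45 percentage points lower from compound 1 to compound 3 (beyond the scatter). Compound 4, `COc1ccc(S(=O)(=O)c2cnc3ccc(C)cc3c2N2CCC(C)CC2)cc1`, differs from compound 1 in one place: methyl in place of fluoro on an aromatic carbon. For the measured compounds named here, no measured step touches this part of the core; the measured steps all change the group on the sulfonyl sulfur, where a number 46 percentage points lower from compound 2 to compound 3 (beyond the scatter). Nothing among them bears directly on the change to compound 4, so no step beyond the scatter is expected in this assay. Compound 4 is therefore estimated at 80%, with a range from 60% to 95%, which means an expected a number 5 percentage points lower from compound 1 to compound 4 (within the scatter).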

Compound 4, a percentage reported as inhibition, at one concentration (the size of the read-out at that concentration, not a potency): 62%
For compound 4 the middle estimate is 18 percentage points above the measured one, within the range that was stated.
By their numbers in this assay, from the lowest: compound 3; then compound 4; then compounds 1 and 2 (each within the scatter of the next).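

The position carrying fluoro on the shared core is not silent in this assay. Methyl in place of fluoro gives a number 23 percentage points lower from compound 1 to compound 4 (beyond the scatter). So a change on this aromatic carbon can matter, as changes to the group on the sulfonyl sulfur already did, even though one heavy atom simply replaces another and neither group has hydrogen-bond donors or acceptors. Nothing measured here explains the drop.

The compounds shown hold only fluoro and methyl at this place, so how chloro, methoxy or plain hydrogen would read there stays open. On these data alone, whether the same swap would have a similar effect with 3-fluoro-4-methylphenyl on the sulfonyl sulfur also stays open.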